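Removing the diglucoside from a heptyl depside: compound 3

The compounds below may be only part of what the source reports. "The series", "measured", "known", "first", "only" and "open" are said of these compounds alone.

Compound 1 `CCCCCCCc1cc(O)cc(OC(=O)c2c(CCCCCCC)cc(O)cc2O[C@@H]2O[C@H](CO)[C@H](O)[C@H](O)[C@H]2O)c1` — > 25000 nM
Compound 2 `CCCCCCCc1cc(O)cc(OC(=O)c2c(CCCCCCC)cc(O)cc2O[C@@H]2O[C@H](CO[C@@H]3O[C@H](CO)[C@H](O)[C@H](O)[C@H]3O)[C@H](O)[C@H](O)[C@H]2O)c1` — > 25000 nM

In a functional assay on KB cells (Homo sapiens) for cytotoxicity, read by colorimetric assay (a higher number here means a weaker inhibitor, a lower number a stronger inhibitor), compound 1 gives > 25000 nM, a limit of the assay and not a number. Compound 2 gives > 25000 nM, again only a limit. Both values sit at the limit of > 25000 nM in this assay, at which 2 of the 2 values shown sit, so between them lies a step that the two limits leave unreadable from compound 1 to compound 2, and compound 1 cannot be placed more closely than at that limit. Compound 3 `CCCCCCCc1cc(O)cc(OC(=O)c2c(O)cc(O)cc2CCCCCCC)c1` differs from compound 1 by hydrogen in place of 3,4,5-trihydroxy-6-(hydroxymethyl)oxan-2-yl on an oxygen on an aromatic ring. Within the data shown here, no measured step bears on this change, so no direction beyond the scatter is expected in this assay, and compound 3 may again return only a limit. Compound 3 is estimated at 20000 nM (range 5000 nM to 25000 nM), an expected step of an at least 1.2-fold lower number from compound 1 to compound 3 (0.09 log units; that floor lies within the scatter).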

Compound 3, half-maximal inhibitory concentration: 13000 nM
For compound 3 the middle estimate is 1.5-fold (0.19 log units) above the measured one; measured number inside the range.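

In this assay, among these compounds, compound 3 gives 13000 nM, the first value that is a number rather than a limit of the assay. From the compounds shown here alone, compound 1 remains a limit at > 25000 nM, and limits still make up most of the series: the limit of > 25000 nM in this assay, at which 2 of the 3 values shown sit. Hydrogen in place of 3,4,5-trihydroxy-6-(hydroxymethyl)oxan-2-yl on this oxygen gives an at least 1.9-fold lower number from compound 1 to compound 3 (0.28 log units; that floor lies within the scatter), so the true size of the step remains unknown and only its floor can be read.

Going by these compounds, whether the step exceeds that floor remains open. Also open, on these data alone, is what a methyl ether or an acetate ester on this oxygen would give, or a longer chain in place of either heptyl chain.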